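This account rests on a few compounds, and the source may have more. Where it says the series, first, only, none or still open, it means among the compounds named here.

Measured compounds in a functional assay on NCI-H460 cells (Homo sapiens) for cytotoxicity, read by MTT assay, with a stated time of 72 h; on this read-out lower numbers stand for stronger inhibition and higher numbers for weaker inhibition:
compound 1 `CC(C)(C)c1[nH]cnc1/C=c1\[nH]c(=O)/c(=C/c2cccc(C(=O)c3ccc(F)cc3)c2)[nH]c1=O`, 3.8 nM
compound 2 `CC(C)(C)c1[nH]cnc1/C=c1\[nH]c(=O)/c(=C/c2cccc(Oc3ccc(F)cc3)c2)[nH]c1=O`, 4 nM
compound 3 `O=C(c1ccc(F)cc1)c1cccc(/C=c2\[nH]c(=O)/c(=C/c3c[nH]cn3)[nH]c2=O)c1`, 278 nM

Compound 2 stands second highest of the three numbers; its nearest neighbour is compound 1, with a 1.1-fold higher number from compound 1 to compound 2 (0.02 log units; within the scatter), a step within the scatter, and its furthest is compound 3. Compound 4 `O=c1[nH]/c(=C\c2cccc(Oc3ccc(F)cc3)c2)c(=O)[nH]/c1=C\c1cccnc1` differs from compound 2 as follows: pyridin-3-yl in place of 5-(tert-butyl)-1H-imidazol-4-yl on a double-bonded chain carbon bound to an aromatic carbon. Going by the values given here, the one measured step that bears on this is a 73-fold higher number from compound 1 to compound 3 (1.86 log units; beyond the scatter), where only the tert-butyl was removed from the 5-(tert-butyl)-1H-imidazol-4-yl group. The change to compound 4 removes that whole group, tert-butyl included, so a step at least as large, towards a higher number, is expected in this assay. For compound 4 the estimate is 600 nM, with a range of 120 nM to 3000 nM, which corresponds to an expected 150-fold higher number from compound 2 to compound 4 (2.18 log units; beyond the scatter).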

Compound 4, half-maximal inhibitory concentration: > 1000 nM
Compound 4 was reported as a limit; the forecaster's own chance of this, stated with the estimate: 10%; at least 1.6-fold (0.22 log units) between middle value and limit.
By their numbers in this assay, from the lowest: compounds 1 and 2 (each within the scatter of the next); then compound 3. At a limit, above all of these: compound 4.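

Exchanging the whole 5-(tert-butyl)-1H-imidazol-4-yl group for pyridin-3-yl on the double-bonded chain carbon gives an at least 250-fold higher number from compound 2 to compound 4 (2.39 log units; beyond the scatter) in this assay. Compounds 1 and 3 showed only the loss of the tert-butyl with the imidazole ring kept; this step shows that the ring itself can be exchanged only at a large cost in this series. The value of compound 4 is a limit, not a number: the limit of > 1000 nM in this assay, at which 1 of the 4 values shown sits.

Still open, on these data alone, is how much of the step belongs to the tert-butyl and how much to the ring. A methyl or an amine on the imidazole ring, or a tert-butyl on the pyridine ring, would bear on that.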